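A few compounds are considered here, and "the series" means these few. Any claim that something is new, unique, unknown or untested is made for them only; others in the source may bear on it.

Among the measured compounds shown here, in an ADME assay on HepG2 2.2.15 cells (Homo sapiens) for cytotoxicity, with a stated time of 9 days (on this read-out higher numbers stand for lower toxicity in this test and lower numbers for higher toxicity in this test), compound 3 `Cn1c(C[S+]([O-])c2ccccc2)nc2c(Cn3ccnc3)c(O)ccc21` gives 557000 nM, the highest of the three numbers known here: compound 1 `Cn1c(CSc2ccccc2)nc2c(CN3CCCC3)c(O)ccc21` gives 227000 nM and compound 2 `Cc1nccn1Cc1c(O)ccc2c1nc(CSc1ccccc1)n2C` gives 101000 nM. Compound 4 `Cn1c(CSc2ccccc2)nc2c(Cn3ccnc3)c(O)ccc21` differs from compound 3 in one place: a group of 7 heavy atoms (6 carbon, 1 sulfur; one six-membered aromatic ring of carbon only) in place of a group of 8 heavy atoms (6 carbon, 1 oxygen, 1 sulfur; one six-membered aromatic ring of carbon only), on a saturated chain carbon bound to an aromatic carbon. For the measured compounds named here, the single measured step, a 2.2-fold lower number from compound 1 to compound 2 (0.35 log units; beyond the scatter), concerns a different position, so no measured step bears directly on this change; what can be said is that compound 1 and compound 2 both carry the phenylsulfanyl group and give the lower numbers among those measured. Compound 4 is therefore expected to give a somewhat lower number than compound 3, a 1.9-fold lower number from compound 3 to compound 4 (0.27 log units; within the scatter), a step that may still fall within the scatter. The estimate for compound 4 in this assay is 300000 nM, with a range from 120000 nM to 700000 nM.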

Compound 4, half-maximal cytotoxic concentration: 76300 nM
Beside the measured number, compound 4's estimate is 3.9-fold (0.59 log units) above it; the whole stated range lies above it.
By their numbers in this assay, from the lowest: compounds 4 and 2 (each within the scatter of the next); then compound 1; then compound 3.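

In this assay the step of a 7.3-fold lower number from compound 3 to compound 4 (0.86 log units; beyond the scatter) is the largest here, and it shows that phenylsulfanyl in place of the group of compound 3 on this saturated chain carbon matters more than either other change. The other steps are a 3.0-fold lower number from compound 1 to compound 4 (0.47 log units; beyond the scatter) for 1H-imidazol-1-yl in place of pyrrolidin-1-yl, and a 1.3-fold lower number from compound 2 to compound 4 (0.12 log units; within the scatter) for hydrogen in place of methyl on an aromatic carbon, which stays within the scatter. No evidence given here accounts for any of these steps. Open, on these data alone, is whether a phenylsulfonyl group would carry the number further in the direction of compound 3. Also open, as far as these compounds go, is whether the same change at this chain carbon would give a similar step with pyrrolidin-1-yl on the core.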